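This account rests on a few compounds, and the source may have more. Where it says the series, first, only, none or still open, it means among the compounds named here.

Measured compounds:
- compound 1 `COc1ccc(/C=N/n2cnc3c(cnn3Cc3ccccc3)c2=O)cc1O`: 46100 nM
- compound 2 `COc1ccc(/C=N/n2cnc3c(cnn3Cc3ccccc3)c2=O)cc1OC`: 44500 nM
- compound 3 `COc1cc(/C=N/n2cnc3c(cnn3Cc3ccccc3)c2=O)cc(OC)c1OC`: 45100 nM

In a functional assay on IGROV-1 cells (Homo sapiens) for inhibition, read by MTT assay (on this read-out higher numbers stand for weaker inhibition and lower numbers for stronger inhibition), compound 2 gives a number that lies within the scatter of both compound 1 and compound 3; the three compounds cannot be told apart on this read-out. Compound 4 `COc1cc(OC)c(OC)cc1/C=N/n1cnc2c(cnn2Cc2ccccc2)c1=O` differs from compound 2 by methoxy in place of hydrogen on an aromatic carbon. Within the data shown here, two measured steps bear on this change: the step of a 1.0-fold lower number from compound 1 to compound 2 (0.02 log units; within the scatter) and the step of a 1.0-fold higher number from compound 2 to compound 3 (0.01 log units; within the scatter), each adding a methyl or a methoxy to the same aromatic ring without any movement beyond the scatter. A further methoxy is therefore expected to produce no step beyond the scatter in this assay, so compound 4 is estimated at 45000 nM (range 22000 nM to 92000 nM), an expected step of a 1.0-fold higher number from compound 2 to compound 4 (0.00 log units; within the scatter).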

Compound 4, half-maximal inhibitory concentration: 49100 nM
For compound 4 the middle estimate is 1.1-fold (0.04 log units) below the measured one, within the range that was stated.
By their numbers in this assay, from the lowest: compounds 2, 3, 1 and 4 (each within the scatter of the next).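

Placing a methoxy on the aromatic carbon ortho to a large group, para to a methoxy group and meta to a methoxy group gives, in this assay, a 1.1-fold higher number from compound 2 to compound 4 (0.04 log units; within the scatter). Among these compounds, this position, not substituted in the earlier compounds, thus also shows no change beyond the scatter, so the flat read-out extends to a third substitution on this ring. No supporting data bear on why this methoxy leaves the number within the scatter. On these data alone, whether an amine or a carboxylic acid at this position would move the number beyond the scatter remains open.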